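The source may hold more compounds than are shown below. What is called first, only, known or untested is meant among the compounds shown, and "the series" means these compounds.

Measured so far:
compound 1 `N=C(N)NS(=O)(=O)c1ccc(/N=C/c2c(Cl)c3ccccc3oc2=O)cc1` — in a functional assay on MCF7 cells (Homo sapiens) for cytotoxicity, read by CCK-8 assay, with a stated time of 48 h (on this read-out higher numbers stand for weaker inhibition and lower numbers for stronger inhibition), compound 1 gives 58 nM
compound 2 `Cc1cc(C)nc(NS(=O)(=O)c2ccc(/N=C/c3c(Cl)c4ccccc4oc3=O)cc2)n1` — in this assay compound 2 gives 20 nM
compound 3 `CC(C)(C)c1cc(C(C)(C)C)c2oc(=O)c(/C=N/c3ccc(S(=O)(=O)NC(=N)N)cc3)c(Cl)c2c1` — in this assay compound 3 gives 18 nM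

Compound 3 holds the lowest number of the three; its gap to compound 2 lies within the scatter, its gap to compound 1 beyond it. Compound 4, `Cc1ccnc(NS(=O)(=O)c2ccc(/N=C/c3c(Cl)c4cc(C(C)(C)C)cc(C(C)(C)C)c4oc3=O)cc2)n1`, is not yet measured. It differs from compound 3 in one place: a group of 7 heavy atoms (5 carbon, 2 nitrogen; one six-membered aromatic ring with 2 hetero atoms) in place of a group of 3 heavy atoms (1 carbon, 2 nitrogen; no ring), on a sulfonamide nitrogen. Going by the values given here, one measured step bears on this change, a closely related exchange on the sulfonamide nitrogen of the core of compound 1: a 2.9-fold lower number from compound 1 to compound 2 (0.46 log units; beyond the scatter). A step of comparable size, lowering the number, is therefore expected in this assay, namely a 2.3-fold lower number from compound 3 to compound 4 (0.35 log units; beyond the scatter). Compound 4 is estimated at 8 nM, with a range from 3 nM to 22 nM.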

Compound 4, half-maximal inhibitory concentration: 32 nM
Beside the measured number, compound 4's estimate is 4.0-fold (0.60 log units) below it; the whole stated range lies below it.
By their numbers in this assay, from the lowest: compounds 3, 2, 4 and 1 (each within the scatter of the next, the first and the last beyond it).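

In this assay the exchange on the sulfonamide nitrogen of the core of compound 3 gives no step beyond the scatter (a 1.8-fold higher number from compound 3 to compound 4 (0.25 log units; within the scatter)). The step beyond the scatter on the core of compound 1 (a 2.9-fold lower number from compound 1 to compound 2 (0.46 log units; beyond the scatter)) therefore does not carry over to this core with 4-methylpyrimidin-2-yl as the entering group. No measurement at hand accounts for the difference between the two steps.

Open, from the compounds shown here alone, is whether that difference follows the core or the entering group, which is not the same in the two steps. Going by these compounds, how an amine or a longer alkyl chain on the sulfonamide nitrogen would read on either core also remains open.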